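Replacing Chloro with a Hydrazide Ether on the Shared Core

A few compounds are considered here, and "the series" means these few. Any claim that something is new, unique, unknown or untested is made for them only; others in the source may bear on it.

In an ADME assay on RAW264.7 cells (Mus musculus) for cytotoxicity, with a stated time of 24 h (a higher number here means a weaker inhibitor, a lower number a stronger inhibitor), compound 1 `COc1ccc(-c2cc(-c3ccc4c(c3)CCCC4)[nH]c(=S)c2C#N)cc1OC` gives 29400 nM. Compound 2 `COc1ccc(-c2cc(-c3ccc4c(c3)CCCC4)nc(Cl)c2C#N)cc1OC` reaches only the limit of this assay, > 50000 nM, so for compound 2 no number is known, only that it lies at the limit of > 50000 nM in this assay, at which 1 of the 2 values shown sits. Among the compounds with values here, the two values thus show compound 1 with a measured concentration and compound 2 beyond the range of the assay, with no computed step between them.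

Compound 3 `COc1ccc(-c2cc(-c3ccc4c(c3)CCCC4)nc(OCC(=O)NN)c2C#N)cc1OC` differs from compound 2 in one place: (aminocarbamoyl)methoxy in place of chloro on an aromatic carbon. Within the data shown here, no measured pair in this set shares that change, so its effect in this assay has no precedent here. Given that compound 2 sits at the limit, > 50000 nM, compound 3 is expected to remain a weak inhibitor, and the step from compound 2 to compound 3 is estimated as an at least 1.1-fold lower number from compound 2 to compound 3 (0.04 log units; that floor lies within the scatter). Compound 3 is therefore estimated at 45000 nM, within a range from 15000 nM to 100000 nM.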

Compound 3, half-maximal inhibitory concentration: 3100 nM
Beside the measured number, compound 3's estimate is 15-fold (1.16 log units) above it; the whole stated range lies above it.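

The place next to the ring nitrogen and ortho to a cyano group proves sensitive to what it carries: in this assay, (aminocarbamoyl)methoxy in place of chloro gives an at least 16-fold lower number from compound 2 to compound 3 (1.20 log units; beyond the scatter) on the shared core. Within the data shown here, the earlier compounds offered no readable step, so this is the first sign that a change at this place moves the number in the direction of stronger inhibition. Going by these compounds, the true size of the step remains unknown because compound 2 has only a limit and no number: the limit of > 50000 nM in this assay, at which 1 of the 3 values shown sits.

With only this one replacement shown, it stays open whether the ether oxygen, the carbonyl or the hydrazide end accounts for the step. A plain methoxy, an amine or a carboxylic acid at this place, or a longer chain, could separate these parts.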